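The compounds below may be only part of what the source reports. "The series", "measured", "known", "first", "only" and "open" are said of these compounds alone.

Measured compounds:
Compound 1, `COc1ccccc1NC(=O)NC1CC(C)(C)Oc2ccc(Br)cc21`: in a functional assay (aorta) with Rattus norvegicus as the target (a lower number here means that less compound is needed, a higher number that more compound is needed for the effect), compound 1 gives > 10000 nM, which is a limit of the assay.
Compound 2, `CC1(C)CC(NC(=O)Nc2ccccc2Cl)c2cc(Cl)ccc2O1`: in this assay compound 2 gives > 300000 nM, again a limit of the assay.

Compound 2 therefore stands at a limit and carries no number of its own. Compound 3, `CC1(C)CC(NC(=O)Nc2ccccc2Cl)c2cc(Br)ccc2O1`, differs from compound 2 by bromo in place of chloro on an aromatic carbon. For the measured compounds named here, no measured step covers this change. For compound 3 no shift beyond the scatter is expected, and a further limit is the likely outcome. The estimate for compound 3 in this assay is 300000 nM, with a range of 50000 nM to 2000000 nM. The step from compound 2 to compound 3 is accordingly expected to be a number no higher from compound 2 to compound 3 (the limit leaves the size open).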

Compound 3, half-maximal effective concentration: > 30000 nM
Compound 3: a limit, no number; the forecaster's own chance of this, stated with the estimate: 85%; the middle value lies beyond the limit too.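

Compound 3 gives > 30000 nM, a limit of the assay. For the compounds shown here, with compound 1 and compound 2 also at limits, no step to compound 3 can be read. From the compounds shown here alone, whether bromo in place of chloro changes the response at all remains open.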